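Shortening the Chain on the Ring Nitrogen by One Carbon

The source may hold more compounds than are shown below. What is called first, only, known or untested is meant among the compounds shown, and "the series" means these compounds.

Three measured compounds share a core bearing an amide to a benzyl group and an alkyl chain on a ring nitrogen: compound 1 `CCCCCNc1cnc(C(=O)NCc2ccccc2)cn1`, compound 2 `CCCCCCCNc1cnc(C(=O)NCc2ccccc2)cn1` with a longer chain, and compound 3 `CCCCCCCCNc1nccnc1C(=O)NCc1ccccc1` with the same substituents arranged differently on the core. In an ADME assay on MDCK cells (Canis lupus familiaris) for cytotoxicity, read by microscopy, with a stated time of 6 days (a higher number here means that more compound is tolerated, a lower number that less compound is tolerated), compound 1 gives > 100000 nM, which is a limit of the assay and not a number. Compound 2 gives > 100000 nM in this assay, again a limit. Compound 3 gives 100000 nM in this assay. The step that the two limits leave unreadable from compound 1 to compound 2 is unreadable; both values sit at the limit of > 100000 nM in this assay, at which 2 of the 3 values shown sit.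

Compound 4 `CCCCCCNc1cnc(C(=O)NCc2ccccc2)cn1` differs from compound 2 by hydrogen in place of methyl on a saturated chain carbon, six bonds along the chain from a nitrogen on an aromatic ring. For the measured compounds named here, the only step bearing on this change is the unreadable one, and none of the three values shows a difference beyond the scatter, so no step in either direction is expected. Compound 4 is expected to show a step of a number no higher from compound 2 to compound 4 (the limit leaves the size open) of no real size, most likely once more only a limit. The estimate for compound 4 is 100000 nM, between 50000 nM and 200000 nM.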

Compound 4, minimum cytotoxic concentration: > 100000 nM
Compound 4 ended at the assay's limit; the forecaster's own chance of this, stated with the estimate: 75%; the middle value lies on the limit itself.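

The steps linking compound 4 with compound 1 and compound 2 in this assay cannot be read, as all three values are limits of the assay and not numbers: the limit of > 100000 nM in this assay, at which 3 of the 4 values shown sit.

The compounds shown leave open how much of compound 1, compound 2 or compound 4 is actually tolerated, and whether chain length matters.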